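A few compounds are considered here, and "the series" means these few. Any claim that something is new, unique, unknown or untested is made for them only; others in the source may bear on it.

Two compounds of one series were tested in a functional assay on C6 cells (Rattus norvegicus) for cytotoxicity, read by MTT assay, with a stated time of 24 h, tested at 200 ug/mL; a lower number here means a stronger effect, a higher number a weaker effect of the compound at the concentration tested. Compound 1 `COc1ccc(-c2cs/c(=N/NC(=O)CSc3nnc(C)s3)n2-c2ccccc2)cc1` gives 22.2% in this assay. Compound 2 `Cc1ccc(-c2cs/c(=N/NC(=O)CSc3ncccn3)n2-c2ccccc2)cc1` gives 43.7% in this assay, the higher of the two numbers; its nearest neighbour is compound 1, which lies lower by a gap beyond the scatter. The two compounds differ in more than one place, so nothing can be said about any single change between them. Compound 3 `COc1ccc(-c2cs/c(=N/NC(=O)CSc3ncccn3)n2-c2ccccc2)cc1` is the next compound to be measured. It differs from compound 2 in one place only: methoxy in place of methyl on an aromatic carbon. Within the data shown here, no measured pair shows this change on its own. Since compound 1 carries the same methoxy group and gives 22.2%, a step downward from compound 2 to compound 3 is expected in this assay, of moderate size and not certainly beyond the scatter, so that the estimated value of compound 3 is 34%, with a range from 18% to 55%, which is the step of a number 9.7 percentage points lower from compound 2 to compound 3 (within the scatter) expected.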

Compound 3, a percentage reported as activity, at one concentration (the size of the read-out at that concentration, not a potency): 37.6%
Compound 3: middle estimate off by 3.6 percentage points, on the low side; the range from low to high includes it.
By their numbers in this assay, from the lowest: compound 1; then compounds 3 and 2 (each within the scatter of the next).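

In this assay, methoxy in place of methyl on the aromatic carbon para to a large group gives a number 6.1 percentage points lower from compound 2 to compound 3 (within the scatter), so this change alone does not separate the two compounds. Among these compounds, with the 4-methoxyphenyl group held constant, pyrimidin-2-yl in place of 5-methyl-1,3,4-thiadiazol-2-yl on the sulfur gives a number 15.4 percentage points higher from compound 1 to compound 3 (beyond the scatter), making the group on the sulfur the only single change here that reaches beyond the scatter. No available measurement accounts for either step.

From the compounds shown here alone, whether the step at the sulfur would recur with the 4-methylphenyl group remains open, since only the methoxy pair shows it. Going by these compounds, it is also open whether an amine or a carboxylic acid in place of the methoxy group would move the number beyond the scatter.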